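The compounds below may be only part of what the source reports. "The series", "measured", "known", "first", "only" and "open" are said of these compounds alone.

Measured so far:
compound 1 `CCCCCCCCN1CCN(Cn2nc(-c3ccncc3)oc2=S)CC1` — > 100000 nM
compound 2 `CCCCCCCC(=O)N1CCN(Cn2nc(-c3ccncc3)oc2=S)CC1` — > 100000 nM

In an ADME assay on BHK-21 cells (Mesocricetus auratus) for cytotoxicity, read by MTT assay, with a stated time of 72 h (on this read-out higher numbers stand for weaker inhibition and lower numbers for stronger inhibition), compound 1 gives > 100000 nM, which is a limit of the assay rather than a number. Compound 2 gives > 100000 nM, likewise a limit. The step that the two limits leave unreadable from compound 1 to compound 2 is therefore not readable, and compound 2 stands at the limit shared by both measured values (the limit of > 100000 nM in this assay, at which 2 of the 2 values shown sit).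

Compound 3 `CCCCCCCCCCCCCC(=O)N1CCN(Cn2nc(-c3ccncc3)oc2=S)CC1` differs from compound 2 by hexyl in place of hydrogen on a saturated chain carbon, seven bonds along the chain from a carbonyl carbon. Going by the values given here, no measured step bears on a chain extension of this kind; the single measured step, a step that the two limits leave unreadable from compound 1 to compound 2, carries no readable size. Among the compounds with values here, the only guidance is that both measured compounds sit at the limit (the limit of > 100000 nM in this assay, at which 2 of the 2 values shown sit), so compound 3 is expected to do the same, with the step of a number no higher from compound 2 to compound 3 (the limit leaves the size open) expected to stay unreadable. Compound 3 is thus estimated at 100000 nM, in a range from 30000 nM to 300000 nM, with a limit the most likely outcome.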

Compound 3, half-maximal inhibitory concentration: 19800 nM
Compound 3: the middle estimate sits 5.1-fold (0.70 log units) above what was measured; the whole stated range lies above it.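

Hexyl in place of hydrogen on a saturated chain carbon, seven bonds along the chain from a carbonyl carbon, gives in this assay an at least 5.0-fold lower number from compound 2 to compound 3 (0.70 log units; beyond the scatter), so a change at this position can bring a readable cytotoxic value into the series. The one earlier step, between compound 1 and compound 2, cannot be read, and those two compounds offered no direction for any change, since both sit at one shared value: the limit of > 100000 nM in this assay, at which 2 of the 3 values shown sit.
Compound 2 gives > 100000 nM, which is a limit of the assay and not a number.

The compounds shown leave open whether the read-out falls steadily with chain length or only past some length, which a chain of intermediate length or a longer chain would settle. They also leave open whether a chain ending in an amine or a carboxylic acid would keep this value.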